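This account rests on a few compounds, and the source may have more. Where it says the series, first, only, none or still open, it means among the compounds named here.

Of the compounds shown here, two have been measured in a physicochemical assay for lipophilicity, read by HPLC, in phosphate buffer, measured as chromatographic lipophilicity, at pH 7.4; on this read-out lower numbers stand for lower lipophilicity and higher numbers for higher lipophilicity. Compound 1 `CCOc1ccc2nc(C(F)(F)F)cc(OCC(=O)Nc3cc(C)cc(C)c3)c2c1` gives 7.55 in this assay, and compound 2 `COc1ccc2nc(C)cc(OCC(=O)Nc3cccc(C)c3)c2c1` gives 4.83. Compound 2 thus stands lowest of the two, with compound 1 well above it, a gap beyond the scatter; the two compounds differ in several places at once, so no single step can be read from that gap.

Compound 3 `COc1ccc2nc(C)cc(OCC(=O)Nc3ccc(Cl)cc3)c2c1` has not yet been measured. It differs from compound 2 in one place only: 4-chlorophenyl in place of 3-methylphenyl on an amide-type nitrogen.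

Among the measured compounds shown here, since no pair of measured compounds differs in just one place, there is no single step to lean on. Going from compound 2 to compound 3, a step of a number 0.17 log units higher from compound 2 to compound 3 (within the scatter) is expected, a shift that would not stand out beyond the scatter in either direction. Compound 3 is therefore estimated at 5 in this assay, within a range from 4.5 to 5.5, because compound 2 sits at 4.83 and the change is small.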

Compound 3, distribution coefficient: 5.15
The estimate for compound 3 lay 0.15 log units below the measured number, and the stated range covers the measured number.
By their numbers in this assay, from the lowest: compound 2; then compound 3; then compound 1.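

In this assay, among the compounds shown here, putting 4-chlorophenyl in place of 3-methylphenyl on the amide-type nitrogen gives the first step that can be read at a single place: a number 0.32 log units higher from compound 2 to compound 3 (beyond the scatter). This position therefore responds to a change of group in this read-out, even though the two groups count the same number of heavy atoms and carry the same kind of aromatic ring, while the steps hidden in the wider gap up to compound 1 still cannot be read. Nothing at hand explains why the step has this size.

The step changes both the substituent and its place on the ring, so a 3-chlorophenyl or 4-methylphenyl group would be needed to tell these two apart. As far as these compounds go, how a phenyl ring carrying an amine or a carboxylic acid would read also stays open.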